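Vero cytotoxicity notes: methoxybenzyl amide series, fluoro analogue

The source may report more compounds than this note shows. Statements on the series, on what has been measured and on what is new or still open speak of the compounds shown alone.

Compound 1 `Cc1c(C(=O)NCc2ccccc2)[n+]([O-])c2cc(F)ccc2[n+]1[O-]` — in an ADME assay on Vero cells (Chlorocebus sabaeus) for cytotoxicity, read by MTT assay, with a stated time of 72 h (a higher number here means a weaker inhibitor, a lower number a stronger inhibitor), compound 1 gives > 100 ug/mL, a limit of the assay.
Compound 2 `COc1ccc(CNC(=O)c2c(C)[n+]([O-])c3ccc(C)cc3[n+]2[O-])cc1` — in this assay compound 2 gives > 30 ug/mL, also a limit of the assay.
Compound 3 `COc1ccc(CNC(=O)c2c(C)[n+]([O-])c3ccc(OC)cc3[n+]2[O-])cc1` — in this assay compound 3 gives "not determined" (no result reported), no result being reported.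

Compound 3 stands without a number in this assay; the two other values shown for the set are not numbers either, each being a limit, as the limit of > 100 ug/mL in this assay, at which 1 of the 3 values shown sits, and the limit of > 30 ug/mL in this assay, at which 1 of the 3 values shown sits, record. Among the compounds with values here, no pair among the measured compounds differs in one place, so no measured step is available for comparison.

Compound 4 `COc1ccc(CNC(=O)c2c(C)[n+]([O-])c3ccc(F)cc3[n+]2[O-])cc1` is the untested member. Compound 4 differs from compound 3 by fluoro in place of methoxy on an aromatic carbon. With compound 3 unmeasured there is no anchor for the size of this step in this assay; the step is expected to lie within the scatter rather than move the value in either direction. The expectation for compound 4 rests on compound 1, which carries the same fluoro substituent and gives > 100 ug/mL in this assay, and on compound 2, which carries the same methoxybenzyl amide and gives > 30 ug/mL in this assay. Compound 4 is therefore estimated at 100 ug/mL in this assay, with a likely range of 30 ug/mL to 300 ug/mL, and the result is expected most often to be reported only as a limit.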

Compound 4, half-maximal inhibitory concentration: > 30 ug/mL
Compound 4 was reported as a limit (the forecaster's own chance of this, stated with the estimate: 75%); the middle value is on the limit's open side.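

In this assay compound 4 gives > 30 ug/mL, a limit of the assay. No new step can be read: the steps to compound 4 from compound 1 and from compound 2 each rest on two limits. The compounds shown leave open where any of them would fall as an actual number in this assay, and whether fluoro in place of methoxy on an aromatic carbon shifts the value at all.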